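A few compounds are considered here, and "the series" means these few. Any claim that something is new, unique, unknown or untested is made for them only; others in the source may bear on it.

Working notes on the series. In a functional assay on SGC-7901 cells (Homo sapiens) for antiproliferative activity, read by sulforhodamine B assay, with a stated time of 72 h (a higher number here means a weaker inhibitor, a lower number a stronger inhibitor), compound 1 `FC(F)(F)c1ccccc1NC(=S)N/N=C/c1ccc2ccccc2n1` gives 20700 nM. Compound 2 `Cc1cccc(NC(=S)N/N=C/c2ccc3ccccc3n2)c1` sits at the limit of > 100000 nM in this assay, at which 2 of the 3 values shown sit. For compound 2 the reading > 100000 nM is a limit of this assay, not a number. Compound 3 `NC(=S)N/N=C/c1ccc2cccnc2n1` is likewise reported only as a limit, > 100000 nM. Among the measured compounds shown here, no step between measured compounds is available, so compound 2 stands simply as one of the two limit values, weaker than compound 1 on the numbers given. Compound 4 `Fc1ccc(NC(=S)N/N=C/c2ccc3ccccc3n2)cc1` is not yet measured; it differs from compound 2 by 4-fluorophenyl in place of 3-methylphenyl on an amide-type nitrogen. In this assay a small step is expected, an at least 1.4-fold lower number from compound 2 to compound 4 (0.15 log units; that floor lies within the scatter), toward the stronger side if anything, and it may not exceed the usual scatter. For compound 4 the estimate is 70000 nM, with a range of 15000 nM to 300000 nM.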

Compound 4, half-maximal inhibitory concentration: 32300 nM
Estimate against measurement, compound 4: 2.2-fold (0.34 log units) above; the range from low to high includes it.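

On the amide-type nitrogen whose other neighbour is the thiocarbonyl carbon, 4-fluorophenyl in place of 3-methylphenyl gives an at least 3.0-fold lower number from compound 2 to compound 4 (0.49 log units; beyond the scatter) in this assay. Among the compounds shown here, this is the only readable step so far, and it shows that activity at this position depends on the aryl group carried there. The step is a floor and not a full size, because compound 2 has a limit and not a number: the limit of > 100000 nM in this assay, at which 2 of the 4 values shown sit.

The compounds shown leave open whether the fluorine, the loss of the methyl or the substituent's placement accounts for the step. An amine or a carboxylic acid on this phenyl ring also remains untested in the compounds shown.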